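From 2-nitrophenyl to 4-fluorophenyl on the sulfonyl sulfur

The source may report more compounds than this note shows. Statements on the series, on what has been measured and on what is new or still open speak of the compounds shown alone.

In a functional assay on HL-60 cells (Homo sapiens) for inhibition, read by CCK-8 assay, with a stated time of 48 h, tested at 20 uM (a higher number here means more inhibition of growth at the concentration tested, a lower number less inhibition of growth), compound 1 `COc1ccc(Cc2nnc(NC(=O)/C(C#N)=C/c3ccccc3OS(=O)(=O)c3ccc(OC)cc3)s2)cc1` with 4-methoxyphenyl on the sulfonyl sulfur gives 100% as its reading. Compound 2 `COc1ccc(Cc2nnc(NC(=O)/C(C#N)=C/c3ccccc3OS(=O)(=O)c3ccc([N+](=O)[O-])cc3)s2)cc1` with 4-nitrophenyl there gives 51% as its reading. Compound 3 `COc1ccc(Cc2nnc(NC(=O)/C(C#N)=C/c3ccccc3OS(=O)(=O)c3ccccc3[N+](=O)[O-])s2)cc1` with 2-nitrophenyl gives 25% as the lowest of the three numbers, beyond the scatter from both others.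

Compound 4 `COc1ccc(Cc2nnc(NC(=O)/C(C#N)=C/c3ccccc3OS(=O)(=O)c3ccc(F)cc3)s2)cc1` has not yet been measured. It carries 4-fluorophenyl in place of 2-nitrophenyl on a sulfonyl sulfur and shares everything else with compound 3.

Two measured steps change this same group and end at compound 3: the large a number 75 percentage points lower from compound 1 to compound 3 (beyond the scatter) and the modest a number 26 percentage points lower from compound 2 to compound 3 (beyond the scatter) in this assay. Read backwards, both point upward for a compound that, like compound 1 and compound 2, has a 4-substituted phenyl group. Among the compounds with values here, the large a number 49 percentage points lower from compound 1 to compound 2 (beyond the scatter) shows how widely such groups can differ, and no fluorinated compound has been measured, so the expectation stays loose.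

A rise beyond the scatter is expected, with the estimated step of a number 45 percentage points higher from compound 3 to compound 4 (beyond the scatter) lying between the sizes of those two steps. The estimate for compound 4 is 70% within an expected range of 42% to 98% at the concentration tested.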

Compound 4, percent growth inhibition at one concentration: 25%
Compound 4: middle estimate off by 45 percentage points, on the high side; the whole stated range lies above it.
By their numbers in this assay, from the lowest: compounds 3 and 4 (each within the scatter of the next); then compound 2; then compound 1.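

In this assay, the change from 2-nitrophenyl to 4-fluorophenyl on the sulfonyl sulfur gives no change at the digits printed from compound 3 to compound 4 (within the scatter), so the higher reading of the 4-nitrophenyl compound does not carry over to this other 4-substituted group, and moving away from 2-nitrophenyl does not in itself raise the reading. Fluoro in place of nitro on the aromatic carbon gives a number 26 percentage points lower from compound 2 to compound 4 (beyond the scatter), and fluoro in place of methoxy gives a number 75 percentage points lower from compound 1 to compound 4 (beyond the scatter), which widens the earlier contrast: the three groups named 4-methoxyphenyl, 4-nitrophenyl and 4-fluorophenyl give three clearly different outcomes, and compound 1 stands apart from all the others by steps beyond the scatter. Nothing in the data at hand explains these differences.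

The compounds shown leave open whether the high reading belongs to the methoxy group alone or also extends to other groups on that aromatic carbon, such as ethoxy, methyl or dimethylamino. Since every reading comes from a single concentration, they also leave open how compound 3 and compound 4 compare across a range of concentrations.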